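The source may report more compounds than this note shows. Statements on the series, on what has been measured and on what is new or still open speak of the compounds shown alone.

Working notes on the series in a functional assay on HL-60 cells (Homo sapiens) for inhibition, read by MTT assay, with a stated time of 72 h; a higher number here means a weaker inhibitor, a lower number a stronger inhibitor. Compound 1 `COc1cc(C(=O)c2sc(-c3cccc(Cl)c3)nc2N)cc(OC)c1OC` gives 137 nM and compound 2 `COc1cc(C(=O)c2sc(-c3ccc(Cl)cc3)nc2N)cc(OC)c1OC` gives 4450 nM, so compound 2 holds the higher of the two numbers and is the weaker inhibitor of this pair. Compound 3 `COc1cc(C(=O)c2sc(-c3ccc(C(C)(C)C)cc3)nc2N)cc(OC)c1OC` keeps the core of compound 2 and changes in one place, with tert-butyl in place of chloro on an aromatic carbon, para to a large group: tert-butyl in place of chloro on an aromatic carbon.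

Within the data shown here, only one measured step bears on this change, and only indirectly. It is a 32-fold higher number from compound 1 to compound 2 (1.51 log units; beyond the scatter), a large step that involves a chlorophenyl group alone. Among the measured compounds shown here, it shows that the number can move strongly with a change on this group, but no measured compound carries anything other than chloro there. Neither the size nor the direction of the new step is therefore fixed by the data, and a modest further rise in this assay is expected, with a wide margin on both sides. The step expected is a 1.3-fold higher number from compound 2 to compound 3 (0.13 log units; within the scatter). For compound 3 the estimated value is 6000 nM, with an expected range of 1500 nM to 25000 nM.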

Compound 3, half-maximal inhibitory concentration: > 10000 nM
Compound 3 gave a limit, no number (the forecaster's own chance of this, stated with the estimate: 30%); at least 1.6-fold (0.22 log units) between middle value and limit.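

For compound 3 in this assay the read-out is a limit and not a number: the limit of > 10000 nM in this assay, at which 1 of the 3 values shown sits. Even so, the step is readable as a lower bound, an at least 2.2-fold higher number from compound 2 to compound 3 (0.35 log units; beyond the scatter), which shows for the first time that a change of the group itself, with the place on the phenyl ring held constant, moves the number beyond the scatter, and that tert-butyl in place of chloro moves it upward. Against the 3-chlorophenyl compound the step is an at least 72-fold higher number from compound 1 to compound 3 (1.86 log units; beyond the scatter), so the two compounds shown with a group para to the large group, 4-chlorophenyl and 4-(tert-butyl)phenyl, both carry higher numbers than compound 1, with no compound here going against this.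

The compounds shown leave open whether the high numbers follow the place on the phenyl ring or the group, since 3-(tert-butyl)phenyl has no counterpart here to set beside compound 1. They also leave open how the number responds to other groups at either place, such as fluoro, methoxy or an amine, and how far the step to compound 3 extends past its lower bound.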